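A few compounds are considered here, and "the series" means these few. Any claim that something is new, unique, unknown or untested is made for them only; others in the source may bear on it.

Three compounds have been measured in a functional assay on SW-620 cells (Homo sapiens) for cytotoxicity, read by MTT assay, with stated times of 4 h and 72 h, tested at 2 uM; a higher number here means a weaker inhibitor, a lower number a stronger inhibitor:

- compound 1 `Cc1cc(Nc2ccc(C(=O)/C=C/c3ccc(F)cc3)cc2)n2nc(SCc3nc4ccccc4[nH]3)nc2n1` gives 85 nM
- compound 2 `Cc1ccc(/C=C/C(=O)c2ccc(Nc3cc(C)nc4nc(SCc5nc6ccccc6[nH]5)nn34)cc2)cc1` gives 1520 nM
- compound 3 `Cc1cc(Nc2ccc(C(=O)/C=C/c3ccc(-n4cccn4)cc3)cc2)n2nc(SCc3nc4ccccc4[nH]3)nc2n1` gives 340 nM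

Compound 2 stands highest of the three numbers in this assay, that is, it is the weakest of these inhibitors: compound 3 is nearest, a step of a 4.5-fold lower number from compound 2 to compound 3 (0.65 log units; beyond the scatter), and compound 1 furthest, a step of an 18-fold higher number from compound 1 to compound 2 (1.25 log units; beyond the scatter) in the other direction.

Compound 4 `Cc1cc(Nc2ccc(C(=O)/C=C/c3ccccc3Cl)cc2)n2nc(SCc3nc4ccccc4[nH]3)nc2n1` is not yet measured. It differs from compound 2 in one place: 2-chlorophenyl in place of 4-methylphenyl on a double-bonded chain carbon bound to a double-bonded chain carbon.

Two measured steps start from, or end at, the methyl-bearing ring of compound 2. Replacing fluoro with that methyl gave an 18-fold higher number from compound 1 to compound 2 (1.25 log units; beyond the scatter), and replacing the methyl with 1H-pyrazol-1-yl gave a 4.5-fold lower number from compound 2 to compound 3 (0.65 log units; beyond the scatter). Among the measured compounds shown here, both other groups tried at this ring gave a lower number than methyl, so a lower number in this assay for compound 4 is expected, likely somewhere between the values of compound 1 and compound 3, though the chlorine sits on a different ring position than either fluoro or 1H-pyrazol-1-yl, and no measured step shows what that shift does. The estimate for compound 4 is 250 nM, with a range of 70 nM to 900 nM, a step of a 6.1-fold lower number from compound 2 to compound 4 (0.78 log units; beyond the scatter).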

Compound 4, half-maximal inhibitory concentration: 680 nM
Compound 4: the middle estimate sits 2.7-fold (0.43 log units) below what was measured, within the range that was stated.
By their numbers in this assay, from the lowest: compound 1; then compounds 3 and 4 (each within the scatter of the next); then compound 2.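

In this assay, replacing 4-methylphenyl with 2-chlorophenyl still lowers the number (a 2.2-fold lower number from compound 2 to compound 4 (0.35 log units; beyond the scatter)), so a lower number at this position does not depend on a group carried at the 4-position of the ring, yet 2-chlorophenyl falls well short of 4-fluorophenyl (an 8.0-fold higher number from compound 1 to compound 4 (0.90 log units; beyond the scatter)). Compound 4 also cannot be separated from the compound carrying 4-(1H-pyrazol-1-yl)phenyl (a 2.0-fold higher number from compound 3 to compound 4 (0.30 log units; within the scatter)), which leaves 4-fluorophenyl as the only group shown here whose number lies beyond the scatter of all the others. No outside measurement is available to explain any of these differences.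

On these data alone, compound 4 changes both the substituent and its place on the ring at once, so the contribution of each remains unknown. A 4-chlorophenyl or 2-fluorophenyl group would help pull the two apart.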